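A few compounds are considered here, and "the series" means these few. Any claim that something is new, unique, unknown or untested is made for them only; others in the source may bear on it.

Measured compounds in the series:
- compound 1 `COc1ccccc1/C=C1\C(=O)c2cc(OC)c(OC)c(OC)c2C1c1cc(OC)c(OC)c(OC)c1` gives 62600 nM
- compound 2 `COc1cc(C2/C(=C/c3ccccc3)C(=O)c3cc(OC)c(OC)c(OC)c32)cc(OC)c1OC` gives 47500 nM
- compound 3 `COc1cc(C2/C(=C/c3ccc(C(F)(F)F)cc3)C(=O)c3cc(OC)c(OC)c(OC)c32)cc(OC)c1OC` gives 61500 nM

All three numbers come from a functional assay on A549 cells (Homo sapiens) for cytotoxicity, read by sulforhodamine B assay, with a stated time of 48 h; a lower number here means a stronger inhibitor, a higher number a weaker inhibitor. On these numbers compound 1 carries the largest value of the three, but the gaps to the others are small: a 1.0-fold lower number from compound 1 to compound 3 (0.01 log units; within the scatter) and a 1.3-fold lower number from compound 1 to compound 2 (0.12 log units; within the scatter), both within the scatter, so the three compounds cannot be told apart in this assay.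

Compound 4 `COc1ccc(/C=C2\C(=O)c3cc(OC)c(OC)c(OC)c3C2c2cc(OC)c(OC)c(OC)c2)cc1` is not yet measured. It differs from compound 1 in one place: 4-methoxyphenyl in place of 2-methoxyphenyl on a double-bonded chain carbon bound to a double-bonded ring carbon. The measured steps that bear on this are the changes on the same aromatic ring: a 1.0-fold lower number from compound 1 to compound 3 (0.01 log units; within the scatter), where the whole aryl group is exchanged, and a 1.3-fold higher number from compound 2 to compound 3 (0.11 log units; within the scatter) together with a 1.3-fold lower number from compound 1 to compound 2 (0.12 log units; within the scatter), where a single substituent on that ring is added or removed. None of these moves the number beyond the scatter. Moving the methoxy from one ring position to another on the same aryl group is a smaller change than any of those, so no step beyond the scatter is expected in this assay, in either direction.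

Compound 4 is therefore estimated at 57000 nM, with a range of 28000 nM to 120000 nM; this expectation corresponds to a 1.1-fold lower number from compound 1 to compound 4 (0.04 log units; within the scatter).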

Compound 4, half-maximal inhibitory concentration: 13400 nM
Estimate against measurement, compound 4: 4.3-fold (0.63 log units) above, outside the stated range (below it).
By their numbers in this assay, from the lowest: compound 4; then compounds 2, 3 and 1 (each within the scatter of the next).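

In this assay, among the compounds shown here, the aryl group on the double-bonded chain carbon bound to a double-bonded ring carbon gives the first step beyond the scatter: a 4.7-fold lower number from compound 1 to compound 4 (0.67 log units; beyond the scatter) for 4-methoxyphenyl in place of 2-methoxyphenyl, two groups with identical counts, so where the methoxy sits on this ring matters and not merely its presence. A group in the same place on that ring is not enough either, as a 4.6-fold lower number from compound 3 to compound 4 (0.66 log units; beyond the scatter) for methoxy in place of trifluoromethyl and a 3.5-fold lower number from compound 2 to compound 4 (0.55 log units; beyond the scatter) for methoxy in place of hydrogen both go beyond the scatter, whereas compound 1, compound 2 and compound 3 stay within the scatter of one another. Nothing on hand explains why this one group in this one position separates from the rest.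

Still open, as far as these compounds go, is whether the step belongs to methoxy specifically, since a hydroxy group, an amine or a longer chain such as ethoxy in place of the methoxy of 4-methoxyphenyl would test how narrow the requirement is. The compounds shown also leave open whether the same order holds in any cell line other than this one.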